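This account rests on a few compounds, and the source may have more. Where it says the series, first, only, none or still open, it means among the compounds named here.

Compound 2 `COc1ccc(/C=C2\CCC/C(=C\c3ccc([N+](=O)[O-])cc3)C2=O)cc1` is the reference point for this step. Within the data shown here, in a physicochemical assay for lipophilicity (on this read-out lower numbers stand for lower lipophilicity and higher numbers for higher lipophilicity), compound 2 gives 5.08, level with compound 1 and together with it the highest of the three numbers so far. Compound 1 `Cc1ccc(/C=C2\CCC/C(=C\c3ccc([N+](=O)[O-])cc3)C2=O)cc1` gives 5.08 in this assay, and the move no change at the digits printed from compound 1 to compound 2 (within the scatter) put methoxy in place of methyl on an aromatic carbon. Compound 3 `COc1cc(/C=C2\CCC/C(=C\c3ccccc3[N+](=O)[O-])C2=O)cc(OC)c1OC` gives 4.86 in this assay, a value within the scatter of compound 2, so all three measured numbers sit in one band. The next compound, compound 4 `O=C1/C(=C/c2ccccc2)CCC/C1=C\c1ccc([N+](=O)[O-])cc1`, is compound 2 with the change (hydrogen in place of methoxy on an aromatic carbon), that is 4-methoxyphenyl to phenyl, para to a large group. Among the measured compounds shown here, only one measured step touches that aromatic carbon, no change at the digits printed from compound 1 to compound 2 (within the scatter), and it swapped one group for another rather than removing one; no measured step here takes a substituent off entirely. With that step flat and the series held in one band, the expectation for compound 4 in this assay is a step of a number 0.08 log units lower from compound 2 to compound 4 (within the scatter), nothing beyond the scatter. Compound 4 is therefore estimated at 5, with a range from 4.6 to 5.4.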

Compound 4, partition coefficient: 5.08
Beside the measured number, compound 4's estimate is 0.08 log units below it, within the range that was stated.
By their numbers in this assay, from the lowest: compounds 3, 1, 2 and 4 (each within the scatter of the next).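

In this assay, among these compounds, hydrogen in place of methoxy on this aromatic carbon gives no change at the digits printed from compound 2 to compound 4 (within the scatter), and this is the first step in which the substituent leaves without another group taking its place. Hydrogen in place of methyl gives no change at the digits printed from compound 1 to compound 4 (within the scatter), so compounds 1, 2 and 4 now cover methyl, methoxy and hydrogen at this place and read level at the digits printed. No available evidence bears on the origin of this flat reading.

Among the compounds shown here, whether it extends to an amine, a carboxylic acid or a longer chain on this aromatic carbon remains open, since hydrogen, methyl and methoxy are the only groups compared here. Compound 3 differs from these compounds in more than one place, so it gives no direct reading on this position.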